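Amino for Nitro, Repeated on a Second Core

A few compounds are considered here, and "the series" means these few. Any claim that something is new, unique, unknown or untested is made for them only; others in the source may bear on it.

Compound 1 `COc1ccccc1/C=C/S(=O)(=O)Cc1ccc(OC)c([N+](=O)[O-])c1` and compound 2 `COc1ccc(CS(=O)(=O)/C=C/c2ccccc2OC)cc1N` share one core and differ in a single place: amino in place of nitro on an aromatic carbon. In a functional assay on DU-145 cells (Homo sapiens) for cytotoxicity, read by trypan blue exclusion, with a stated time of 96 h (a lower number here means a stronger inhibitor, a higher number a weaker inhibitor), compound 1 gives 20000 nM, and compound 2 gives 7500 nM; the step is a 2.7-fold lower number from compound 1 to compound 2 (0.43 log units; beyond the scatter). Compound 3 `COc1ccc(CS(=O)(=O)/C=C/c2c(OC)cc(O)cc2OC)cc1[N+](=O)[O-]` is built on a different core, and the difference between the two cores is not broken down here. In this assay compound 3 gives 5000 nM. Compound 4 `COc1ccc(CS(=O)(=O)/C=C/c2c(OC)cc(O)cc2OC)cc1N` has not yet been measured; it comes from compound 3 by the same change, (amino in place of nitro on an aromatic carbon), at a place described in exactly the same words. Because the earlier step was a 2.7-fold lower number from compound 1 to compound 2 (0.43 log units; beyond the scatter), a step of a 2.5-fold lower number from compound 3 to compound 4 (0.40 log units; beyond the scatter) is expected here. Compound 4 is therefore estimated at 2000 nM in this assay, likely between 800 nM and 5000 nM.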

Compound 4, half-maximal inhibitory concentration: 200 nM
Estimate against measurement, compound 4: 10-fold (1.00 log units) above; measured number below the stated range.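

In this assay, amino in place of nitro on an aromatic carbon again gives a lower number, and this time a much lower one (a 25-fold lower number from compound 3 to compound 4 (1.40 log units; beyond the scatter)). The direction of the change carried over from the core of compound 1 to the core of compound 3, but its size did not: the same change on two cores in this assay, a 2.7-fold lower number (0.43 log units; beyond the scatter) from compound 1 to compound 2 and a 25-fold lower number (1.40 log units; beyond the scatter) from compound 3 to compound 4, 9.4-fold (0.97 log units) apart, beyond the scatter of two such steps. With only two cores shown, and the difference between them not broken down, these compounds cannot tell which part of the core goes with the larger step, or why the size differs.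

The compounds shown leave open whether a different group in the same place, such as an acetamide or a carboxylic acid, would also give a lower number than nitro. They also leave open how large the step from nitro to amino would be on a third core.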